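The source may hold more compounds than are shown below. What is called first, only, known or untested is meant among the compounds shown, and "the series" means these compounds.

In a physicochemical assay for lipophilicity, at pH 7.4 (a lower number here means a more polar compound, a higher number a more lipophilic compound), compound 3 `O=C(Nc1ccc2[nH]c(=O)[nH]c2c1)[C@H]1CCCN1C(=O)C1(c2cccc(Cl)c2)CCCC1` gives 4.4, within the usual scatter of compound 2 `O=C(Nc1ccc2[nH]ncc2n1)[C@H]1COCCN1C(=O)C1(c2ccc(Cl)cc2)CC(F)(F)C1` at 4.5, while compound 1 `O=C(Nc1ccc2[nH]ccc2n1)[C@H]1CCCN1C(=O)C1(c2cccc(Cl)c2)CCCC1` stands well apart at 5.9. Compound 4 `O=C(Nc1cnc2[nH]ncc2c1)[C@H]1CCCN1C(=O)C1(c2cccc(Cl)c2)CCCC1` differs from compound 3 by a group of 9 heavy atoms (6 carbon, 3 nitrogen; one five-membered aromatic ring with 2 hetero atoms, one six-membered aromatic ring with 1 hetero atom) in place of a group of 10 heavy atoms (7 carbon, 2 nitrogen, 1 oxygen; one five-membered aromatic ring with 2 hetero atoms, one six-membered aromatic ring of carbon only), on an amide-type nitrogen. Like the group in compound 1, the entering group has one six-membered aromatic ring with 1 hetero atom. For the measured compounds named here, the only measured step bearing on this is a number 1.50 log units lower from compound 1 to compound 3 (beyond the scatter), which is large and beyond the scatter. A partial reversal of that step, about half its size, is therefore expected in this assay, estimated as a number 0.80 log units higher from compound 3 to compound 4 (beyond the scatter). For compound 4 the expected value is 5.2, with an estimated range from 4.6 to 5.8.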

Compound 4, distribution coefficient: 4.9
For compound 4 the middle estimate is 0.30 log units above the measured one, and the stated range covers the measured number.
By their numbers in this assay, from the lowest: compounds 3 and 2 (each within the scatter of the next); then compound 4; then compound 1.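

At this amide-type nitrogen, a six-membered aromatic ring with 1 hetero atom does not by itself set the number in this assay: the group in compound 4 has such a ring, as does the group in compound 1, yet the data show a number 1.00 log units lower from compound 1 to compound 4 (beyond the scatter). Compound 4 falls between the other two, with a number 0.50 log units higher from compound 3 to compound 4 (beyond the scatter). No measurement shown accounts for either step. Still open, as far as these compounds go, is where a single-ring group on this nitrogen, such as a phenyl ring carrying an amine or a carboxylic acid, would fall.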